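Benzotriazole series: liver microsomal stability, bromo for cyano

The compounds below may be only part of what the source reports. "The series", "measured", "known", "first", "only" and "open" are said of these compounds alone.

Measured compounds in an ADME assay on microsomes from liver (Rattus norvegicus, strain Wistar) for metabolic stability, tested at 2.5 uM; a lower number here means slower removal, a higher number faster removal of the compound:
compound 1 `Fc1ccc(-c2ccc(Cn3nnc4ccccc43)cc2)c(F)c1` — 6.4 mL/min/g
compound 2 `Fc1cc(Cl)ccc1-c1ccc(Cn2nnc3ccccc32)cn1` — 0.8 mL/min/g
compound 3 `N#Cc1cccc2c1nnn2Cc1ccc(-c2ccc(Cl)cc2F)nc1` — 0.1 mL/min/g

Compound 3 stands lowest of the three numbers in this assay; compound 2 is nearest, compound 1 furthest, both beyond the scatter. Compound 4 `Fc1cc(Cl)ccc1-c1ccc(Cn2nnc3c(Br)cccc32)cn1` differs from compound 3 by bromo in place of cyano on an aromatic carbon. Within the data shown here, the one measured step that bears on this place is an 8.0-fold lower number from compound 2 to compound 3 (0.90 log units; beyond the scatter), which shows what cyano at this position adds over hydrogen; no measured pair shows bromo. Removing cyano is therefore expected to undo part of that step, with bromo presumably landing between the hydrogen and cyano cases. For compound 4 the expected step is a 3.5-fold higher number from compound 3 to compound 4 (0.54 log units; beyond the scatter), a modest rise. Compound 4 is thus estimated at 0.35 mL/min/g, with a range from 0.1 mL/min/g to 1.2 mL/min/g.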

Compound 4, intrinsic clearance in a liver preparation (reported as CLH), per the amount of preparation that the assay uses: 0.4 mL/min/g
Estimate against measurement, compound 4: 1.1-fold (0.06 log units) below; low and high end bracket the measured number.
By their numbers in this assay, from the lowest: compound 3; then compounds 4 and 2 (each within the scatter of the next); then compound 1.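

In this assay bromo in place of cyano on an aromatic carbon gives a 4.0-fold higher number from compound 3 to compound 4 (0.60 log units; beyond the scatter) and so does not keep the low number of compound 3. Against hydrogen, the same position gives a 2.0-fold lower number from compound 2 to compound 4 (0.30 log units; within the scatter) and so does not separate bromo from hydrogen here, leaving cyano as the only one of the three groups set apart beyond the scatter. From the compounds shown here alone, whether an amine or a carboxylic acid on this carbon would sit with cyano or with bromo stays open. Nothing available gives a reason for the gap between cyano and bromo.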